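A Trifluoromethyl Added to the Phenyl of Compound 3

This account rests on a few compounds, and the source may have more. Where it says the series, first, only, none or still open, it means among the compounds named here.

Of the compounds shown here, three sharing one core have been measured in a functional assay on DU-145 cells (Homo sapiens) for inhibition, read by MTT assay, with a stated time of 24 h; on this read-out lower numbers stand for stronger inhibition and higher numbers for weaker inhibition. Compound 1 `CCCCCCCCn1cc(COC2(C(F)(F)F)Oc3ccccc3C=C2C(=O)OCC)nn1` gives only a limit of the assay, > 150000 nM. Compound 2 `CCOC(=O)C1=Cc2ccccc2OC1(OCc1cn(CC(=O)Nc2ccc(OC)cc2)nn1)C(F)(F)F` gives 32700 nM in this assay. Compound 3 `CCOC(=O)C1=Cc2ccccc2OC1(OCc1cn(-c2ccccc2)nn1)C(F)(F)F` likewise gives only a limit of the assay, > 150000 nM. Compound 3 thus stands at the limit, where two of the three values sit (the limit of > 150000 nM in this assay, at which 2 of the 3 values shown sit); the step that the two limits leave unreadable from compound 1 to compound 3 cannot be read, whereas an at least 4.5-fold higher number from compound 2 to compound 3 (0.66 log units; beyond the scatter) is read from the limit.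

The unmeasured compound 4 `CCOC(=O)C1=Cc2ccccc2OC1(OCc1cn(-c2cccc(C(F)(F)F)c2)nn1)C(F)(F)F` differs from compound 3 by trifluoromethyl in place of hydrogen on an aromatic carbon. Going by the values given here, none of the measured steps touches a group on this phenyl: the steps of an at least 4.5-fold lower number from compound 1 to compound 2 (0.66 log units; beyond the scatter) and an at least 4.5-fold higher number from compound 2 to compound 3 (0.66 log units; beyond the scatter) exchange the group on the aromatic nitrogen itself, and both are at least modest. Compound 3 offers no numbered starting point, and the addition of a trifluoromethyl has no measured counterpart among these three. The expectation for compound 4 is accordingly that it again falls at or around the limit in this assay, with a step of a number no higher from compound 3 to compound 4 (the limit leaves the size open) that is not expected to be resolvable. Compound 4 is estimated at 150000 nM in this assay, within a range from 40000 nM to 400000 nM.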

Compound 4, half-maximal inhibitory concentration: > 150000 nM
Compound 4: no number, only a limit; the forecaster's own chance of this, stated with the estimate: 70%; the middle value sits exactly at the limit.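

In this assay compound 4 gives only a limit, > 150000 nM. Going by these compounds alone, this is the first change on the phenyl itself, and adding trifluoromethyl to that ring does not bring the value off the limit. Within the data shown here, the exchange on the aromatic nitrogen reads as an at least 4.5-fold higher number from compound 2 to compound 4 (0.66 log units; beyond the scatter), which matches what the plain phenyl gave, while the steps between the compounds at the limit cannot be read, so the trifluoromethyl addition has no measurable size here and the ((4-methoxyphenyl)carbamoyl)methyl compound remains the only one with a number: the limit of > 150000 nM in this assay, at which 3 of the 4 values shown sit.

From the compounds shown here alone, whether any group on this phenyl can bring the value below the limit stays open, and an amine or a carboxylic acid on the same aromatic carbon would be one way to ask. Also open, going by these compounds, is what trifluoromethyl does where a numbered value exists as a starting point, for example in place of the methoxy group on the (4-methoxyphenyl)carbamoyl side chain.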